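The source may report more compounds than this note shows. Statements on the series, on what has been measured and on what is new or still open speak of the compounds shown alone.

Working notes on the series. Three compounds of the shared core have numbers in a functional assay on HT-29 cells (Homo sapiens) for cytotoxicity, read by sulforhodamine B assay; on this read-out lower numbers stand for stronger inhibition and higher numbers for weaker inhibition. Compound 1 `C=C1[C@@H](OC(C)=O)C[C@@H]2[C@](C)(CO[Si](C)(C)C(C)(C)C)[C@H](OC(C)=O)CC[C@@]2(C)[C@@H]1C[C@@H](Nc1ccccc1F)C1=CCOC1=O` gives 3710 nM. Compound 2 `C=C1[C@@H](OC(C)=O)C[C@@H]2[C@](C)(COC=O)[C@H](OC(C)=O)CC[C@@]2(C)[C@@H]1C[C@@H](Nc1ccc(OC)c(OC)c1)C1=CCOC1=O` gives 42800 nM. Compound 3 `C=C1[C@@H](OC(C)=O)C[C@@H]2[C@](C)(CO[Si](C)(C)C(C)(C)C)[C@H](OC(C)=O)CC[C@@]2(C)[C@@H]1C[C@@H](Nc1ccccc1C(=O)O)C1=CCOC1=O` gives 5340 nM. Compound 3 stands second highest of the three; its nearest neighbour is compound 1, and the step of a 1.4-fold higher number from compound 1 to compound 3 (0.16 log units; within the scatter) lies within the scatter, so the two are not separated. Compound 2 lies well above it.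

The next step goes from compound 3 to compound 4 `C=C1[C@@H](OC(C)=O)C[C@@H]2[C@](C)(CO[Si](C)(C)C(C)(C)C)[C@H](OC(C)=O)CC[C@@]2(C)[C@@H]1C[C@@H](Nc1ccc(OC)c(OC)c1)C1=CCOC1=O`: 3,4-dimethoxyphenyl in place of 2-carboxyphenyl on an amine nitrogen. Among the measured compounds shown here, no measured step covers this exchange on the amine nitrogen; the only measured step, from compound 1 to compound 3, swaps two other groups on that ring and stayed within the scatter. Compound 2 also carries the 3,4-dimethoxyphenyl but differs from compound 4 elsewhere on the shared core, so its value can only hint that this group may sit higher. For compound 4 a step of a 2.2-fold higher number from compound 3 to compound 4 (0.35 log units; beyond the scatter) is expected, upward in this assay. Compound 4 is therefore estimated at 12000 nM, in the range 4000 nM to 40000 nM.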

Compound 4, half-maximal inhibitory concentration: 5330 nM
Compound 4: middle estimate off by 2.3-fold (0.35 log units), on the high side; measured number inside the range.
By their numbers in this assay, from the lowest: compounds 1, 4 and 3 (each within the scatter of the next); then compound 2.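

On the amine nitrogen, 3,4-dimethoxyphenyl and 2-carboxyphenyl are not separated in this assay, with a 1.0-fold lower number from compound 3 to compound 4 (0.00 log units; within the scatter), and 3,4-dimethoxyphenyl and 2-fluorophenyl are not separated either, with a 1.4-fold higher number from compound 1 to compound 4 (0.16 log units; within the scatter). The 3,4-dimethoxyphenyl group therefore does not carry the high number of compound 2: with that group held constant, the exchange on the oxygen on a saturated carbon, a group of 7 heavy atoms in place of a group of 2 heavy atoms, gives an 8.0-fold lower number from compound 2 to compound 4 (0.90 log units; beyond the scatter). Nothing available explains either finding.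

Open, from the compounds shown here alone, is how a plain alkyl chain or a cyclohexyl group on the amine nitrogen would read in this assay. Also open, going by these compounds, is whether a free hydroxyl in place of the silicon-bearing group would read closer to compound 2 or compound 4.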